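Swapping a Carboxy for a Phenyl on the Core

The source may report more compounds than this note shows. Statements on the series, on what has been measured and on what is new or still open speak of the compounds shown alone.

Compounds measured so far:
- compound 1, `CC1(C)CC(=O)C2=C(C1)NC(c1ccccc1)=CC2c1ccc([N+](=O)[O-])cc1`: "not active" (no number reported)
- compound 2, `COc1ccc(C2C=C(c3ccccc3)NC3=C2C(=O)CC(C)(C)C3)cc1`: "not active" (no number reported)
- compound 3, `CC1(C)CC(=O)C2=C(C1)NC(C(=O)O)=CC2c1ccccc1`: 17.1%

For the measured compounds named here, in an assay on isolated protein for inhibition of glucose-6-phosphatase catalytic subunit 1 (Homo sapiens), read by inositol phosphate accumulation, with a stated time of 30 min, tested at 100 uM (on this read-out higher numbers stand for more inhibition at the one concentration tested (going by the name of the read-out) and lower numbers for less inhibition), compound 3 is the only compound of the three with a reported number; compound 1 and compound 2 were each reported as not active, without a figure. Compound 3 therefore stands alone as the one entry with measurable inhibition, and nothing in the reported numbers ranks it against the other two beyond that.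

Compound 4, `CC1(C)CC(=O)C2=C(C1)NC(c1ccccc1)=CC2c1ccccc1`, has not yet been measured in this assay. It differs from compound 3 in a single place: phenyl in place of carboxy on a double-bonded ring carbon. Compound 4 thus carries two phenyl groups on the shared core, which makes it a close relative of compound 1 and compound 2, both carrying a phenyl at this same position.

Going by the values given here, no step between two measured compounds is available to set the size of this change. Still, a step downward from compound 3 is expected, a number 12.1 percentage points lower from compound 3 to compound 4 (beyond the scatter), because compound 1 gives "not active" (no number reported) and compound 2 gives "not active" (no number reported) with a phenyl in this position. The expected size is close to the edge of the usual scatter. For compound 4 the estimate is 5%, ranging from 0% to 15%, with a fair chance that only a "not active" outcome is reported.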

Compound 4, a percentage reported as inhibition, at one concentration (the size of the read-out at that concentration, not a potency): "not active" (no number reported)
No number was reported for compound 4; no gap can be computed for the estimate.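

In this assay, for the compounds shown here, compound 4 gives "not active" (no number reported) while compound 3 gives 17.1% and so no step between the two can be read. No measured evidence bears on this result. The compounds shown leave open how large the change from carboxy to phenyl actually is, with compound 1, compound 2 and compound 4 all lacking a number.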